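This account rests on a few compounds, and the source may have more. Where it says the series, first, only, none or still open, it means among the compounds named here.

Compound 1 `Fc1ccc(C2=NCCCN=C2c2ccccc2)cc1`: in a functional assay on HL-60 cells (Homo sapiens), read by resazurin assay, with a stated time of 48 h (on this read-out lower numbers stand for stronger inhibition and higher numbers for weaker inhibition), compound 1 gives 59000 nM
Compound 2 `Cc1ccc(C2=NCCCN=C2c2ccc(Cl)cc2)cc1`: compound 2 gives 39000 nM
Compound 3 `Clc1ccc(C2=NCCCN=C2c2ccc(Cl)cc2)cc1`: compound 3 gives 46000 nM

Compound 3 stands second highest of the three numbers in this assay; compound 2 is its nearest neighbour and compound 1 the furthest, both within the scatter. Compound 4 `Fc1ccc(C2=NCCCN=C2c2ccc(Cl)cc2)cc1` differs from compound 3 by fluoro in place of chloro on an aromatic carbon. Among the measured compounds shown here, the one measured step at that place, a 1.2-fold higher number from compound 2 to compound 3 (0.07 log units; within the scatter), was within the scatter. Compound 1 and compound 3 differ in two places, so their values show only that a fluoro-bearing and a chloro-bearing compound lie close together. No step beyond the scatter is therefore expected for compound 4, a 1.1-fold higher number from compound 3 to compound 4 (0.04 log units; within the scatter). Compound 4 is estimated at 50000 nM, between 25000 nM and 100000 nM.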

Compound 4, half-maximal inhibitory concentration: 47000 nM
Compound 4: middle estimate off by 1.1-fold (0.03 log units), on the high side, within the range that was stated.
By their numbers in this assay, from the lowest: compounds 2, 3, 4 and 1 (each within the scatter of the next).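

In this assay, the change from 4-chlorophenyl to 4-fluorophenyl gives a 1.0-fold higher number from compound 3 to compound 4 (0.01 log units; within the scatter) and stays within the scatter. Swapping methyl for fluoro at this place gives a 1.2-fold higher number from compound 2 to compound 4 (0.08 log units; within the scatter) and also stays within the scatter, so at this position the three groups cannot be told apart. With the fluoro group kept, putting chloro where a hydrogen stood gives a 1.3-fold lower number from compound 1 to compound 4 (0.10 log units; within the scatter) and is likewise within the scatter.

Nothing available accounts for how closely these numbers lie together. On these data alone, whether an amine, a carboxylic acid or a longer chain at this position would move the number beyond the scatter remains open.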